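Anilino thiazoline series: removing chloro from compound 3

The compounds below may be only part of what the source reports. "The series", "measured", "known", "first", "only" and "open" are said of these compounds alone.

Of the compounds shown here, three of a shared core have been measured in a functional assay on a subcellular fraction from brain (Rattus norvegicus) for inhibition, read by scintillation counting, with a stated time of 5 min; a lower number here means a stronger inhibitor, a higher number a weaker inhibitor. Compound 1 `CCc1cccc(CC)c1NC1=NCCC2(CCCCC2)S1` gives 7900 nM in this assay. Compound 2 `Cc1cc(C)c(NC2=NCCC3(CCCCC3)S2)c(C)c1` gives 9300 nM. For the measured compounds named here, compound 3 `Cc1ccc(NC2=NCCC3(CCCCC3)S2)cc1Cl` gives 89100 nM, the highest of the three numbers, and its gap to compound 2 and to compound 1 lies beyond the usual scatter in each case, so compound 3 is the weakest inhibitor of the three so far.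

The next compound to be measured is compound 4 `Cc1ccc(NC2=NCCC3(CCCCC3)S2)cc1`. Relative to compound 3, the change is hydrogen in place of chloro on an aromatic carbon, ortho to a methyl group and meta to the large group. Going by the values given here, no measured pair shows this change on its own, so the size of its effect has no direct precedent here. The two compounds carrying only alkyl groups on the aromatic ring, compound 1 and compound 2, both sit well below compound 3 in this assay, which gives some reason to expect that loss of the chloro brings the number down rather than up. The step from compound 3 to compound 4 is expected to be a 2.2-fold lower number from compound 3 to compound 4 (0.35 log units; beyond the scatter), towards stronger inhibition but of modest size. Compound 4 is therefore estimated at 40000 nM in this assay, with a range from 10000 nM to 150000 nM.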

Compound 4, half-maximal inhibitory concentration: 31600 nM
Compound 4: the middle estimate sits 1.3-fold (0.10 log units) above what was measured; the range from low to high includes it.
By their numbers in this assay, from the lowest: compounds 1 and 2 (each within the scatter of the next); then compound 4; then compound 3.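

In this assay the series now has its first step that can be read on its own: hydrogen in place of chloro on the aromatic carbon ortho to a methyl group and meta to the large group gives a 2.8-fold lower number from compound 3 to compound 4 (0.45 log units; beyond the scatter) and so moves towards stronger inhibition. For this pair, the chloro is not needed for inhibition at this position, and compound 4 at 31600 nM shows that the methyl group alone on the aromatic ring still leaves a measurable inhibitor. No measurement here accounts for the size or direction of this step.

This single pair cannot show whether the step is specific to chloro or how far it depends on the methyl group staying in place, so a fluoro, a methoxy or a carboxylic acid at the same carbon remains an open comparison. Going by these compounds, it also remains open whether replacing the methyl group of compound 4 with hydrogen or an ethyl group would shift the number further, and whether hydrogen in place of chloro would give a step of similar size on a ring carrying other substituents.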